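Swapping phenylsulfanyl for nitro when only limits exist

The source may report more compounds than this note shows. Statements on the series, on what has been measured and on what is new or still open speak of the compounds shown alone.

In a functional assay on the whole organism with Rattus norvegicus as the target (a higher number here means that more compound is needed for the effect, a lower number that less compound is needed), three compounds with a shared core have so far returned only limits, not numbers. Compound 1 `CCOC(=O)C(=O)Nc1nc(-c2ccc(F)cc2)cs1` gives > 10 mg/kg as a limit. Compound 2 `CCOC(=O)C(=O)Nc1nc(-c2ccc(Oc3ccccc3)cc2)cs1` gives > 30 mg/kg as a limit. From the compounds shown here alone, compound 3 `CCOC(=O)C(=O)Nc1nc(-c2ccc(Sc3ccccc3)cc2)cs1` gives > 3 mg/kg as a limit, so its true value is unknown and it cannot be ranked against the other two.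

The next compound, compound 4 `CCOC(=O)C(=O)Nc1nc(-c2ccc([N+](=O)[O-])cc2)cs1`, carries nitro in place of the phenylsulfanyl on an aromatic carbon. The change in detail is nitro in place of phenylsulfanyl on an aromatic carbon and it falls at the same place where the measured compounds differ from one another.

Going by the values given here, the steps that bear on it are a step that the two limits leave unreadable from compound 1 to compound 2 and a step that the two limits leave unreadable from compound 1 to compound 3 and a step that the two limits leave unreadable from compound 2 to compound 3 and none of them has a readable size. They therefore offer no firm direction for this swap. Like compound 4, compound 1 has no second ring at this place, and its limit of > 10 mg/kg is the closest guide available.

The expected move, a step that the limit leaves unreadable from compound 3 to compound 4 is only a loose estimate. For compound 4 the estimated value is 10 mg/kg with an expected range from 1.5 mg/kg to 50 mg/kg and another limit would be no surprise.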

Compound 4, dose for half-maximal effect: > 100 mg/kg
Compound 4 was reported as a limit; the forecaster's own chance of this, stated with the estimate: 65%; middle value at least 10-fold (1.00 log units) away from the limit.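

In this assay compound 4 gives > 100 mg/kg, which is a limit and not a number. Going by these compounds alone, compound 1, compound 2 and compound 3 also have only limits, so no step from any of them to compound 4 can be read. The compounds shown leave open the true dose for each compound and how fluoro, phenoxy, phenylsulfanyl and nitro rank against one another.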